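Swapping the urea arm of compound 2 for an aryl amide

The source may report more compounds than this note shows. Statements on the series, on what has been measured and on what is new or still open speak of the compounds shown alone.

In a functional assay on RPMI-8226 cells (Homo sapiens) for inhibition, read by sulforhodamine B assay, with a stated time of 48 h (a lower number here means a stronger inhibitor of growth, a higher number a weaker inhibitor of growth), compound 2 `COc1cc(-c2nn(-c3cccc(NC(=O)Nc4ccc(Cl)c(Cl)c4)c3)cc2-c2ccncc2)ccc1Cl` gives 388 nM, the lowest of the three numbers measured. Compound 3 `O=C(Nc1cccc(-n2cc(-c3ccncc3)c(-c3ccc(Cl)c(O)c3)n2)c1)Nc1ccc(Cl)c(Cl)c1` gives 1030 nM and compound 1 `COc1cc(-c2nn(-c3cccc(NC(=O)c4cccc(C(F)(F)F)c4)c3)cc2-c2ccncc2)ccc1Cl` gives 1570 nM. The change now in question leads to compound 4 `COc1cc(-c2nn(-c3cccc(NC(=O)c4ccc(Cl)c(C(F)(F)F)c4)c3)cc2-c2ccncc2)ccc1Cl`: 4-chloro-3-(trifluoromethyl)phenyl in place of (3,4-dichlorophenyl)amino on a carbonyl carbon.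

Going by the values given here, the one measured step at that place is a 4.0-fold lower number from compound 1 to compound 2 (0.61 log units; beyond the scatter), which brought in the (3,4-dichlorophenyl)amino group that compound 4 gives up. The other measured step, a 2.7-fold higher number from compound 2 to compound 3 (0.42 log units; beyond the scatter), concerns an oxygen on an aromatic ring and does not bear on this change. Among the compounds with values here, the group entering compound 4 is not the one that left compound 1, so the step from compound 1 is only a rough guide, and the data do not show what that difference contributes. On that basis, a modest move to a higher number is expected in this assay, estimated as a 2.6-fold higher number from compound 2 to compound 4 (0.41 log units; beyond the scatter). For compound 4 the estimated value is 1000 nM, with an expected range of 350 nM to 2800 nM.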

Compound 4, concentration for 50% growth inhibition: 1620 nM
Compound 4: middle estimate off by 1.6-fold (0.21 log units), on the low side; low and high end bracket the measured number.
By their numbers in this assay, from the lowest: compound 2; then compounds 3, 1 and 4 (each within the scatter of the next).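

In this assay, 4-chloro-3-(trifluoromethyl)phenyl in place of (3,4-dichlorophenyl)amino on the carbonyl carbon gives a 4.2-fold higher number from compound 2 to compound 4 (0.62 log units; beyond the scatter), so a second aryl amide also falls short of the urea arm of compound 2. The added chloro on the aromatic carbon makes no real difference within the amide arm, with a 1.0-fold higher number from compound 1 to compound 4 (0.01 log units; within the scatter), so this substituent does not recover the lower number of compound 2. Nothing available here explains the gap between the urea and the amides.

From the compounds shown here alone, whether that gap follows the amino nitrogen of the urea or the change from chloro to trifluoromethyl on the ring remains open, as compound 2 and compound 4 differ in both. Going by these compounds, how a morpholine or a carboxylic acid on that aromatic ring would read is also open.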